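Moving the Bromine on the Phenoxy Ring of Compound 2

The source may report more compounds than this note shows. Statements on the series, on what has been measured and on what is new or still open speak of the compounds shown alone.

Measured compounds:
compound 1, `NC1=NC2(CCOCC2)N(OCCCOc2cccc(Cl)c2)C(N)=N1`: 520 nM
compound 2, `NC1=NC2(CCSCC2)N(OCCCOc2ccc(Br)cc2)C(N)=N1`: 350 nM
compound 3, `NC1=NC2(CCOCC2)N(OCCCOc2ccc(Br)cc2)C(N)=N1`: 310 nM

Of the compounds shown here, three sharing one core have been tested in a functional assay on HL-60 cells (Homo sapiens) for antiproliferative activity, read by MTT assay, with a stated time of 72 h; on this read-out higher numbers stand for weaker inhibition and lower numbers for stronger inhibition. In this assay compound 1 gives 520 nM, compound 2 gives 350 nM and compound 3 gives 310 nM. Compound 2 sits between the other two: its gap to compound 3 and its gap to compound 1 are both within the scatter, so the three numbers are not distinguishable from one another.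

Compound 4, `NC1=NC2(CCSCC2)N(OCCCOc2cccc(Br)c2)C(N)=N1`, has not yet been measured. It differs from compound 2 by 3-bromophenyl in place of 4-bromophenyl on an oxygen on a saturated carbon. Among the compounds with values here, the only measured step that touches the phenoxy ring is the one from compound 1 to compound 3, a 1.7-fold lower number from compound 1 to compound 3 (0.22 log units; within the scatter), which swaps both the halogen and its position on the ring and still stays within the scatter. Within the data shown here, no measured step isolates the position of a bromine alone, so the bearing of that step on compound 4 is indirect.

With that single, flat precedent, compound 4 is expected to show a step of a 1.1-fold higher number from compound 2 to compound 4 (0.06 log units; within the scatter) in this assay, that is, nothing beyond the scatter. The value of compound 4 in this assay is therefore estimated at 400 nM, with a range from 200 nM to 800 nM.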

Compound 4, half-maximal inhibitory concentration: 200 nM
Compound 4: middle estimate off by 2.0-fold (0.30 log units), on the high side; the range from low to high includes it.
By their numbers in this assay, from the lowest: compounds 4, 3, 2 and 1 (each within the scatter of the next, the first and the last beyond it).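

In this assay, within the data shown here, the step of a 1.8-fold lower number from compound 2 to compound 4 (0.24 log units; within the scatter) is the first that changes only where the bromine sits on the phenoxy ring, leaving the shared core and the chain untouched. The earlier step of a 1.7-fold lower number from compound 1 to compound 3 (0.22 log units; within the scatter) exchanged the halogen and its place together, so it could not say what the place of the bromine alone does; this step can, and it shows that 3-bromophenyl and 4-bromophenyl cannot be told apart on this read-out in compounds built on the core of compound 2. No measurement or other information is available here that explains this step.

The compounds shown leave open whether the same exchange of 4-bromophenyl for 3-bromophenyl would also stay within the scatter on the core of compound 3. They also leave open whether a carboxylic acid, a nitrile or an amine on the phenyl ring in place of the bromine, or a longer chain to the phenoxy oxygen, would produce a step beyond the scatter.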